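Replacing pyrrolidin-1-yl with hexylamino in compound 2

A few compounds are considered here, and "the series" means these few. Any claim that something is new, unique, unknown or untested is made for them only; others in the source may bear on it.

In a functional assay on B16-F10 cells (Mus musculus) for inhibition, read by MTT assay, with a stated time of 48 h (a lower number here means a stronger inhibitor, a higher number a weaker inhibitor), compound 1 `COc1ccc(/C=C/c2cc(OC)cc(OC)c2/C=C/C(=O)N2CCC(Cl)CC2)cc1` gives 4690 nM and compound 2 `COc1ccc(/C=C/c2cc(OC)cc(OC)c2/C=C/C(=O)N2CCCC2)cc1` gives 9280 nM. These two values lie within the scatter of each other, so compound 2 cannot be ranked against compound 1.

Compound 3 `CCCCCCNC(=O)/C=C/c1c(/C=C/c2ccc(OC)cc2)cc(OC)cc1OC` has not yet been measured. Its difference from compound 2 is hexylamino in place of pyrrolidin-1-yl on a carbonyl carbon. Among the compounds with values here, the only measured step that bears on this, a 2.0-fold higher number from compound 1 to compound 2 (0.30 log units; within the scatter), is also an exchange on a carbonyl carbon, and it stays within the scatter. Within the data shown here, no measured compound carries hexylamino, so this step offers limited guidance.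

No change beyond the scatter is expected, and the estimated step is a 1.4-fold lower number from compound 2 to compound 3 (0.15 log units; within the scatter). For compound 3 the expected value is 6500 nM, with an estimated range of 1800 nM to 24000 nM.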

Compound 3, half-maximal inhibitory concentration: 7180 nM
The estimate for compound 3 lay 1.1-fold (0.04 log units) below the measured number; measured number inside the range.
By their numbers in this assay, from the lowest: compounds 1, 3 and 2 (each within the scatter of the next).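

In this assay, hexylamino, with no ring and with one hydrogen-bond donor, is accepted on this carbonyl carbon with the readings still within the scatter of both ring amides (a 1.3-fold lower number from compound 2 to compound 3 (0.11 log units; within the scatter)) and (a 1.5-fold higher number from compound 1 to compound 3 (0.18 log units; within the scatter)). Across compound 1, compound 2 and compound 3, the exchange of a ring amide for an open chain therefore gives no readable difference, and the loss of the ring and the gain of the amide hydrogen arrive together, so neither can be judged alone. No supporting data are available to explain this result.

On these data alone, whether a carboxylic acid or an amine at the end of the hexyl chain, or a longer chain, would move the number beyond the scatter remains open. A short chain such as methylamino would also help separate chain length from the amide hydrogen.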